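The compounds below may be only part of what the source reports. "The series", "measured", "known", "first", "only" and "open" are said of these compounds alone.

Measured so far:
compound 1, `OC[C@H]1O[C@@H](n2cnc3c(CSc4cccc(Br)c4)ncnc32)[C@H](O)[C@@H]1O`: 363 nM
compound 2, `OC[C@H]1O[C@@H](n2cnc3c(CSc4ccc(I)cc4)ncnc32)[C@H](O)[C@@H]1O`: 69.2 nM

In an assay on isolated protein for binding affinity to Equilibrative nucleoside transporter 1 (Homo sapiens) (a lower number here means a stronger inhibitor, a higher number a weaker inhibitor), compound 2 gives 69.2 nM and stands lowest of the two numbers. Compound 1 gives 363 nM in this assay. Among the measured compounds shown here, the single step between them, a 5.2-fold lower number from compound 1 to compound 2 (0.72 log units; beyond the scatter), places 4-iodophenyl instead of 3-bromophenyl on the sulfur and is the only comparison available.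

Compound 3, `CC(C)(C)c1ccc(SCc2ncnc3c2ncn3[C@@H]2O[C@H](CO)[C@@H](O)[C@H]2O)cc1`, differs from compound 2 by tert-butyl in place of iodo on an aromatic carbon. For the measured compounds named here, no measured step exchanges one group for another on the same aromatic carbon; the one step seen swaps both the halogen and the place on the ring, so it bears on this change only loosely. With the 4-substituted phenyl kept, the expectation is a step that stays near the scatter, a 1.2-fold higher number from compound 2 to compound 3 (0.09 log units; within the scatter), direction uncertain. Compound 3 is therefore estimated at 85 nM in this assay, with a range from 30 nM to 250 nM.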

Compound 3, half-maximal inhibitory concentration: 331000 nM
Compound 3: the middle estimate sits 3900-fold (3.59 log units) below what was measured; the measured number lies above the stated range.
By their numbers in this assay, from the lowest: compound 2; then compound 1; then compound 3.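

In this assay, the group on the aromatic carbon carrying iodo in compound 2 proves far from interchangeable: tert-butyl in place of iodo gives a 4800-fold higher number from compound 2 to compound 3 (3.68 log units; beyond the scatter), so keeping the substituent at the same place on the ring does not preserve the low number. The 4-(tert-butyl)phenyl group also stands well behind 3-bromophenyl, with a 910-fold higher number from compound 1 to compound 3 (2.96 log units; beyond the scatter), a change of a size that the two halogen-bearing compounds alone gave no sign of. Nothing available accounts for this loss.

Open, on these data alone, is whether the loss is particular to tert-butyl or extends to other groups at this place, such as methyl, methoxy or an amine. Also open, as far as these compounds go, is how much of the gap between the two halogen-bearing compounds belongs to the halogen and how much to its place, which 4-bromophenyl would help separate.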